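The source may report more compounds than this note shows. Statements on the series, on what has been measured and on what is new or still open speak of the compounds shown alone.

Compound 1 `COc1ccc(-c2cc3ccccc3nc2/C=C/C(=O)c2ccc(OC)cc2OC)cc1`: 7040 nM
Compound 2 `COc1ccc(-c2cc3ccccc3nc2/C=C/C(=O)c2ccc(OC)c(OC)c2)cc1`: 7540 nM
Compound 3 `COc1ccc(-c2cc3ccccc3nc2/C=C/C(=O)c2ccc([N+](=O)[O-])cc2)cc1`: 6470 nM

All three were tested in a functional assay on NCI-H460 cells (Homo sapiens) for antiproliferative activity, read by XTT assay, with a stated time of 72 h; on this read-out higher numbers stand for weaker inhibition and lower numbers for stronger inhibition. Compound 3 stands at the low end of the three numbers, yet the steps to it, a 1.1-fold lower number from compound 1 to compound 3 (0.04 log units; within the scatter) and a 1.2-fold lower number from compound 2 to compound 3 (0.07 log units; within the scatter), lie within the scatter, as does a 1.1-fold higher number from compound 1 to compound 2 (0.03 log units; within the scatter); the three cannot be told apart. Compound 4 `COc1ccc(-c2cc3ccccc3nc2/C=C/C(=O)c2ccc[nH]2)cc1` differs from compound 3 by 1H-pyrrol-2-yl in place of 4-nitrophenyl on a carbonyl carbon. Going by the values given here, no measured step exchanges the ring on the carbonyl carbon for a five-membered ring; the known steps only swap groups on a six-membered ring, and each stays within the scatter. For compound 4 the step of a 1.1-fold higher number from compound 3 to compound 4 (0.03 log units; within the scatter) is therefore expected to be small, with no clear direction. Compound 4 is estimated at 7000 nM, between 3000 nM and 16000 nM.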

Compound 4, half-maximal inhibitory concentration: > 10000 nM
Compound 4: a limit, no number; the forecaster's own chance of this, stated with the estimate: 10%; middle value at least 1.4-fold (0.15 log units) away from the limit.
By their numbers in this assay, from the lowest: compounds 3, 1 and 2 (each within the scatter of the next). At a limit, above all of these: compound 4.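

In this assay compound 4 gives > 10000 nM, which is a limit and not a number. With 1H-pyrrol-2-yl on the carbonyl carbon, a five-membered aromatic ring replaces the six-membered ones, and the steps read an at least 1.5-fold higher number from compound 3 to compound 4 (0.18 log units; that floor lies within the scatter), an at least 1.3-fold higher number from compound 2 to compound 4 (0.12 log units; that floor lies within the scatter) and an at least 1.4-fold higher number from compound 1 to compound 4 (0.15 log units; that floor lies within the scatter). Going by these compounds alone, this is the first hint that this position may respond to a change of ring, but every floor lies within the scatter, so no real difference is established.

On these data alone, how far compound 4 truly lies from the others stays open. Also open, as far as these compounds go, is whether an amine, a carboxylic acid or a longer chain on the carbonyl carbon would give a step beyond the scatter.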